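This account rests on a few compounds, and the source may have more. Where it says the series, first, only, none or still open, it means among the compounds named here.

Compound 1 `O=C(COc1ccc([N+](=O)[O-])cc1)N/N=C/c1ccccc1OC(=O)c1sc2ccccc2c1Cl` was tested in an ADME assay on Huh-7 cells (Homo sapiens) for cytotoxicity, read by a luciferase reporter, with a stated time of 72 h (a lower number here means that less compound is tolerated, a higher number that more compound is tolerated), where compound 1 gives 40000 nM. For the measured compounds named here, this is the higher of the two numbers measured so far, meaning more of compound 1 is tolerated by the cells than of the other compound. The companion, compound 2 `COc1ccc(C(=O)Cc2ccc3ccccc3c2/C=N/NC(=O)COc2ccc([N+](=O)[O-])cc2)cc1`, differs in more than one place; in this assay compound 2 gives 9000 nM, a number beyond the usual scatter of this measurement and so a real gap.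

The step under study leads from compound 1 to compound 3 `CC(Oc1ccc([N+](=O)[O-])cc1)C(=O)N/N=C/c1ccccc1OC(=O)c1sc2ccccc2c1Cl`. The change is small: methyl in place of hydrogen on a saturated chain carbon bound to a carbonyl carbon and an oxygen on an aromatic ring. It adds a single carbon on a saturated chain carbon bound to a carbonyl carbon and an oxygen on an aromatic ring, leaving the rest of the molecule untouched.

Going by the values given here, no measured pair shows this kind of change, so the expectation for compound 3 rests on compound 1 alone. A step from compound 1 to compound 3 of about a 1.3-fold lower number from compound 1 to compound 3 (0.12 log units; within the scatter) is expected, which is no change beyond the scatter. Compound 3 is therefore estimated at 30000 nM, within a range of 10000 nM to 70000 nM.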

Compound 3, half-maximal cytotoxic concentration: 19000 nM
Beside the measured number, compound 3's estimate is 1.6-fold (0.20 log units) above it; low and high end bracket the measured number.
By their numbers in this assay, from the lowest: compound 2; then compound 3; then compound 1.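

In this assay, a single added carbon at this position is enough to move the reading: methyl in place of hydrogen on a saturated chain carbon bound to a carbonyl carbon and an oxygen on an aromatic ring gives a 2.1-fold lower number from compound 1 to compound 3 (0.32 log units; beyond the scatter), a modest step. This position is therefore not silent in this assay, and this first change here points towards less compound being tolerated. No measurement shown here accounts for the shift.

As far as these compounds go, with only hydrogen and methyl at this carbon, it remains open whether a larger group, such as an ethyl or a longer chain, would lower the number further, or whether the step would stop at methyl. From the compounds shown here alone, it is also open how a group of another kind at this carbon, such as an amine or a carboxylic acid, would read in this assay.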